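Aromatic substituent change in a small amide series

This account rests on a few compounds, and the source may have more. Where it says the series, first, only, none or still open, it means among the compounds named here.

Values in a functional assay on the whole organism for antagonist activity, with Mus musculus as the target; on this read-out lower numbers stand for an effect already at smaller amounts and higher numbers for an effect only at larger amounts of compound:
compound 1 (`CCC(=O)N(c1ccc(F)cc1)C1CCCC1N(C)C`) gives 0.08 mg/kg
compound 2 (`CCC(=O)N(c1ccc(F)c(Cl)c1)C1CCCC1N(C)C`) gives 2 mg/kg
compound 3 (`CCC(=O)N(c1ccc(C#N)cc1)C1CCCC1N(C)C`) has no value yet

For the measured compounds named here, compound 1 holds the lower of the two numbers in this assay (0.08 mg/kg) and compound 2 is its only neighbour. The change under study is cyano in place of fluoro on an aromatic carbon, para to a large group (cyano in place of fluoro on an aromatic carbon). Going by the values given here, only one measured step bears on it, and only loosely: chloro in place of hydrogen on an aromatic carbon gave a 25-fold higher number from compound 1 to compound 2 (1.40 log units; beyond the scatter) which is large and beyond the scatter. That step shows that the number can move far with one aromatic substituent. Among the compounds with values here, no measured step replaces fluoro, so the size of this change stays uncertain. A higher number is expected, with a step smaller than the measured one, though the range stays wide. The expected step is a 7.5-fold higher number from compound 1 to compound 3 (0.88 log units; beyond the scatter) in this estimate. For compound 3 the estimated value is 0.6 mg/kg with an expected range from 0.08 mg/kg to 5 mg/kg in this assay (an estimate, not a measurement).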

Compound 3, dose for half-maximal effect: 40 mg/kg
Compound 3: the middle estimate sits 67-fold (1.82 log units) below what was measured; measured number outside the range, above it.
By their numbers in this assay, from the lowest: compound 1; then compound 2; then compound 3.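

Working notes on the series: in this assay, the aromatic carbon para to a large group tolerates a change of substituent far less well than the earlier pair could indicate, with cyano in place of fluoro giving a 500-fold higher number from compound 1 to compound 3 (2.70 log units; beyond the scatter). For the compounds shown here, this is the first measured step that replaces fluoro itself, and its size shows that fluoro cannot be exchanged freely for cyano at this place on the core of compound 1. It is also larger than a 25-fold higher number from compound 1 to compound 2 (1.40 log units; beyond the scatter), the step for chloro in place of hydrogen on an aromatic carbon, so a single exchange at the fluoro-bearing carbon can move the number further than that addition did, and nothing at hand explains the size of the new step.

Going by these compounds, whether the higher number follows from the loss of fluoro or from the arrival of cyano stays open, and a methyl group, a methoxy group or chloro on this same carbon would help separate the two. Also open, on these data alone, is whether a step of this size would hold with a longer chain in place of the propanoyl amide or with a second aromatic substituent present.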